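The source may report more compounds than this note shows. Statements on the series, on what has been measured and on what is new or still open speak of the compounds shown alone.

The account follows the step from compound 2 `CC(C)=CCC/C(C)=C/Cc1c(O)cc2c(c1O)C(=O)C[C@@H](c1ccc(O)c(O)c1)O2` to compound 4 `COc1cc([C@@H]2CC(=O)c3c(cc(O)c(C/C=C(\C)CCC=C(C)C)c3O)O2)cc(O)c1O`, read in a functional assay on MCF7 cells (Homo sapiens) for cytotoxicity, with a stated time of 72 h; a lower number here means that less compound is needed, a higher number that more compound is needed for the effect.

Where compound 2 stands is known only as a limit: in this assay compound 2 gives < 10000 nM, which is a limit of the assay and not a number. Compound 1 `CC(C)=CCC/C(C)=C/Cc1c(O)cc2c(c1O)C(=O)C[C@@H](c1cc(O)cc(O)c1)O2` sits at the same limit, giving < 10000 nM in this assay. Compound 3 `C=C(C)C(O)CC/C(C)=C/Cc1c(O)cc2c(c1O)C(=O)C[C@@H](c1ccc(O)c(OC)c1)O2` sits at the other limit, giving > 10000 nM in this assay.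

The change from compound 2 to compound 4 is methoxy in place of hydrogen on an aromatic carbon.

Among the compounds with values here, only one measured step is available, a step that the two limits leave unreadable from compound 1 to compound 2, and its size cannot be read, since both of its ends are limits, (the limit of < 10000 nM in this assay, at which 2 of the 3 values shown sit). Within the data shown here, compound 3 carries a methoxy on its aryl ring and sits at the limit of > 10000 nM in this assay, at which 1 of the 3 values shown sits, but it differs from compound 2 in more than one place, so it shows no step of its own. Among the measured compounds shown here, no measured step therefore speaks to the size or direction of the change in hand, and no shift beyond the usual scatter can be predicted either way.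

Compound 4 is accordingly expected to sit close to the limit, with an estimate of 8000 nM spanning 2000 nM to 30000 nM. The step expected from this estimate is a step that the limit leaves unreadable from compound 2 to compound 4.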

Compound 4, half-maximal effective concentration: < 10000 nM
Compound 4 ended at the assay's limit (the forecaster's own chance of this, stated with the estimate: 55%); the middle value lies beyond the limit too.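

Compound 4 stands at a limit of this assay, as do compound 1 and compound 2, so the steps from compound 2 to compound 4 and from compound 1 to compound 4 join limits, not numbers, and cannot be read. The compounds shown leave open whether methoxy in place of hydrogen shifts the half-maximal effective concentration in either direction, and by how much.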